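The compounds below may be only part of what the source reports. "The series", "measured", "known", "first", "only" and "open" are said of these compounds alone.

Measured compounds and their results:

- Compound 1, `Nc1ccccc1NC(=O)c1ccc(CSC(=S)N2CCc3ccc([N+](=O)[O-])cc32)cc1`, gives 39.6% in a functional assay on MGC-803 cells (Homo sapiens) for antiproliferative activity, read by CCK-8 assay, with a stated time of 72 h, tested at 8 uM; on this read-out lower numbers stand for a weaker effect and higher numbers for a stronger effect at the one concentration tested.
- Compound 2, `Nc1ccccc1NC(=O)c1ccc(CSC(=S)N2CCCC2)cc1`, gives 83.4% in this assay.
- Compound 3, `COC(=O)c1ccc2c(c1)CCN2C(=S)SCc1ccc(C(=O)Nc2ccccc2N)cc1`, gives 73.1% in this assay.

Among these three numbers, compound 3 stands second highest. Its nearest neighbour is compound 2, whose number is higher by a margin that lies beyond the usual scatter; compound 1 lies furthest away, with a much lower number, again beyond the scatter.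

Compound 4, `Nc1ccccc1NC(=O)c1ccc(CSC(=S)N2CCc3ccccc32)cc1`, has not yet been measured. It differs from compound 3 in one place only: hydrogen in place of methoxycarbonyl on an aromatic carbon. Among the compounds with values here, no measured pair shows this particular change, so its effect is uncertain. Because compound 1 gives 39.6% and compound 2 gives 83.4%, the known numbers span a wide range, and compound 3 sits in the upper part of it. The step is expected to be small, of the size a number 1.9 percentage points higher from compound 3 to compound 4 (within the scatter), and may not go beyond the scatter. Compound 4 is therefore estimated at 75%, within a range from 55% to 90%.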

Compound 4, a percentage reported as inhibition, at one concentration (the size of the read-out at that concentration, not a potency): 87%
Compound 4: the middle estimate sits 12 percentage points below what was measured, and the stated range covers the measured number.
By their numbers in this assay, from the lowest: compound 1; then compound 3; then compounds 2 and 4 (each within the scatter of the next).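

Replacing methoxycarbonyl with hydrogen on this aromatic carbon gives a number 13.9 percentage points higher from compound 3 to compound 4 (beyond the scatter) in this assay, so the effect at the one concentration tested does not depend on the ester and is stronger without it. Replacing nitro with hydrogen on an aromatic carbon gives a number 47.4 percentage points higher from compound 1 to compound 4 (beyond the scatter), so in both compound 1 and compound 3 the added group comes with a lower number than the unsubstituted ring. Exchanging pyrrolidin-1-yl for 2,3-dihydro-1H-indol-1-yl gives a number 3.6 percentage points higher from compound 2 to compound 4 (within the scatter), so the fused ring offers no clear gain over the simpler ring in this assay.

Nothing available explains why these numbers move as they do. As far as these compounds go, it remains open whether a smaller group such as fluorine, or an amine or a carboxylic acid, on this aromatic carbon would also give a lower number.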